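From dimethylamino to nitro: what one measured step suggests

The source may report more compounds than this note shows. Statements on the series, on what has been measured and on what is new or still open speak of the compounds shown alone.

Compound 1 `O=c1cc(/C=C/c2ccc(Cl)cc2)occ1O` - 1950 nM
Compound 2 `CN(C)c1ccc(/C=C/c2cc(=O)c(O)co2)cc1` - 3050 nM

In a functional assay, with a stated time of 10 min (a higher number here means a weaker inhibitor, a lower number a stronger inhibitor), compound 2 lies within the usual scatter of compound 1, so the two cannot be ranked. Compound 3 `O=c1cc(/C=C/c2ccc([N+](=O)[O-])cc2)occ1O` carries nitro in place of dimethylamino on an aromatic carbon and is still unmeasured. Among the measured compounds shown here, the only measured step at this place is a 1.6-fold higher number from compound 1 to compound 2 (0.19 log units; within the scatter) and it stayed within the scatter. For the measured compounds named here, one step is thin evidence, and no measured compound carries nitro, so no shift beyond the scatter is expected. The expected step is a 1.2-fold lower number from compound 2 to compound 3 (0.09 log units; within the scatter) and this is only an estimate. For compound 3 the estimated value is 2500 nM (1000 nM to 6500 nM).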

Compound 3, half-maximal inhibitory concentration: 1700 nM
Estimate against measurement, compound 3: 1.5-fold (0.17 log units) above; measured number inside the range.
By their numbers in this assay, from the lowest: compounds 3, 1 and 2 (each within the scatter of the next).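

In this assay, nitro in place of dimethylamino gives a 1.8-fold lower number from compound 2 to compound 3 (0.25 log units; within the scatter), and nitro in place of chloro gives a 1.1-fold lower number from compound 1 to compound 3 (0.06 log units; within the scatter). Chloro, dimethylamino and nitro at this place, on the aromatic ring and para to a large group, therefore cannot be ranked, as all three compounds lie within the scatter of one another. Nothing measured here offers an explanation for this. As far as these compounds go, whether a primary amine, a carboxylic acid or a longer chain at this place would give a step beyond the scatter remains open. So does whether any change elsewhere on the shared core would do so.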